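The compounds below may be only part of what the source reports. "The series", "measured", "known", "first", "only" and "open" are said of these compounds alone.

Series notes. Compound 1 `Clc1cc(N2CC[C@H]3CN[C@H]3C2)cnc1Cl` gives in a functional assay on HEK293 cells for agonist activity at Neuronal acetylcholine receptor; alpha3/beta4 (Homo sapiens), read by FLIPR (a higher number here means that more compound is needed for the effect, a lower number that less compound is needed), a value of 9.9 nM; compound 3 `Brc1cc(N2CC[C@H]3CN[C@H]3C2)cnc1Br` gives 8.2 nM; compound 2 `Clc1cc(N2CC[C@@H]3CN[C@@H]3C2)cnc1Cl` gives 110 nM, the highest of the three numbers. Among the measured compounds shown here, the only single-place step measured so far is an 11-fold higher number from compound 1 to compound 2 (1.05 log units; beyond the scatter), a result that rests on (the fact that compounds 1 and 2 differ only in the configuration as drawn). Compound 4 `Cc1cc(N2CC[C@@H]3CN[C@@H]3C2)cnc1Cl` differs from compound 2 by methyl in place of chloro on an aromatic carbon — a methyl in place of chloro on an aromatic carbon, two atoms from the ring nitrogen. For the measured compounds named here, no measured step bears on such an exchange: the stereo step says nothing about it, and compound 1 beside compound 3 shows only what two halogens at that place give. The expected step of a 1.2-fold higher number from compound 2 to compound 4 (0.07 log units; within the scatter) is therefore none beyond the scatter. Compound 4 is estimated at 130 nM, range 50 nM to 350 nM.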

Compound 4, half-maximal effective concentration: 71 nM
Compound 4: middle estimate off by 1.8-fold (0.26 log units), on the high side, within the range that was stated.
By their numbers in this assay, from the lowest: compounds 3 and 1 (each within the scatter of the next); then compounds 4 and 2 (each within the scatter of the next).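

In this assay methyl in place of chloro gives a 1.5-fold lower number from compound 2 to compound 4 (0.19 log units; within the scatter) and so, on the core of compound 2, this aromatic carbon two atoms from the ring nitrogen holds a non-halogen group with no shift beyond the scatter. Earlier compounds carried only halogens at this place. Open, going by these compounds, is whether methyl gives the same step in the configuration of compound 1, and what an ethyl, methoxy or amine group gives at this place. Nothing known about these compounds explains this step.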